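This account rests on a few compounds, and the source may have more. Where it says the series, first, only, none or still open, it means among the compounds named here.

Measured in a functional assay on SK-MEL-28 cells (Homo sapiens) for inhibition, read by MTT assay, with a stated time of 48 h; on this read-out lower numbers stand for stronger inhibition and higher numbers for weaker inhibition:
- compound 1 `CS(=O)(=O)c1ccc(-c2nc3ccccn3c2Sc2ccccc2)cc1`: 61900 nM
- compound 2 `c1ccc(Sc2c(-c3cccs3)nc3ccccn23)cc1`: 85300 nM
- compound 3 `Clc1ccc(Sc2c(-c3cccs3)nc3ccccn23)cc1`: 77300 nM

At 77300 nM, compound 3 lies within the scatter of both other compounds, so the three values form a single narrow band with no order among them. The next compound, compound 4 `Clc1ccc(Sc2c(-c3ccccc3)nc3ccccn23)cc1`, keeps the chloro of compound 3 and changes one group: phenyl in place of thiophen-2-yl on an aromatic carbon. In short, phenyl takes the place of thiophen-2-yl on an aromatic carbon.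

Within the data shown here, only one measured step links two compounds that differ in one place: a 1.1-fold lower number from compound 2 to compound 3 (0.04 log units; within the scatter). That step concerns the chloro and not the group being exchanged, so it bears on the change only indirectly. Among the measured compounds shown here, no measured step isolates the exchange itself. Compound 1 offers a partial hint, as it has no thiophen-2-yl on that carbon but a six-membered aromatic ring of carbon only, itself substituted, and still gives 61900 nM, inside the same band. No step beyond the scatter is therefore expected in this assay, and no direction can be favoured. The expected change is small: a 1.1-fold lower number from compound 3 to compound 4 (0.04 log units; within the scatter). For compound 4 the estimated value is 70000 nM, with an expected range of 35000 nM to 130000 nM.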

Compound 4, half-maximal inhibitory concentration: 74000 nM
Compound 4: middle estimate off by 1.1-fold (0.02 log units), on the low side, within the range that was stated.
By their numbers in this assay, from the lowest: compounds 1, 4, 3 and 2 (each within the scatter of the next).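

In this assay, among these compounds, the exchange of thiophen-2-yl for phenyl on this aromatic carbon gives a 1.0-fold lower number from compound 3 to compound 4 (0.02 log units; within the scatter) and is the first measured step to isolate this change, with the chloro of compound 3 kept in compound 4. The group that leaves is a five-membered aromatic ring with a sulfur atom and a hydrogen-bond acceptor, whereas the group that enters is a six-membered aromatic ring of carbon only with no hydrogen-bond acceptor, and this difference leaves the two compounds within the scatter of each other. No measurement bearing on this outcome is available to explain it.

The four compounds shown all keep an aromatic ring on this carbon and all lie within one narrow band, so they do not show whether any group placed here can move the number beyond the scatter. As far as these compounds go, it remains open whether an amine or a short alkyl chain in place of the ring, or a carboxylic acid on the phenyl of compound 4, would leave the number in that band or take it outside.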